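Indole enamide calpain-1 series: chloro to iodo at the indole carbon

The compounds below may be only part of what the source reports. "The series", "measured", "known", "first", "only" and "open" are said of these compounds alone.

Measured in an assay on isolated protein for inhibition of Calpain-1 catalytic subunit (Homo sapiens), read by fluorescence, with a stated time of 60 min (on this read-out lower numbers stand for stronger inhibition and higher numbers for weaker inhibition), so far:
- compound 1 `COCCN/C(=C1/N=C(C)N(CCOC)C1=O)c1cc2ccccc2[nH]1`: 20 nM
- compound 2 `COCCCN/C(=C1/N=CN(CCOC)C1=O)c1cc2ccccc2[nH]1`: 1020 nM
- compound 3 `COCCN/C(=C1/N=CN(CCOC)C1=O)c1[nH]c2ccccc2c1Cl`: > 1000 nM

Compound 3 carries a chloro on the five-membered aromatic ring of the shared core. In this assay compound 3 gives only a limit, > 1000 nM, not a number; compound 3 thus sits at the limit of > 1000 nM in this assay, at which 1 of the 3 values shown sits. Among the compounds with values here, compound 1 and compound 2 each differ from compound 3 in more than one place; compound 1 shows 20 nM and compound 2 shows 1020 nM; no single-change step connects any two of the measured compounds, so no measured step size is available for this change.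

Compound 4 `COCCN/C(=C1/N=CN(CCOC)C1=O)c1[nH]c2ccccc2c1I` is the next entry. It differs from compound 3 in one place: iodo in place of chloro on an aromatic carbon. Only the halogen changes; the rest of the shared core, both methoxyalkyl chains and the enamine link remain as in compound 3.

Given that compound 3 is reported only as a limit, the step to compound 4 can only be framed relative to that limit. The exchange of one halogen for another at the same aromatic carbon is expected to give a step no larger than the usual scatter, with no clear direction, so compound 4 is expected to stay at or near the limit, with an expected step that the limit leaves unreadable from compound 3 to compound 4. Compound 4 is therefore estimated at 2000 nM, within a range from 600 nM to 8000 nM, and it is likely that the assay again returns only a limit rather than a number.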

Compound 4, half-maximal inhibitory concentration: 1080 nM
Compound 4: middle estimate off by 1.9-fold (0.27 log units), on the high side; the measured number falls inside the stated range.
By their numbers in this assay, from the lowest: compound 1; then compounds 2 and 4 (each within the scatter of the next).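

In this assay compound 3 gives only a limit of > 1000 nM and not a number. Within the data shown here, compound 4 gives 1080 nM in this assay and so no step from compound 3 to compound 4 can be read. The compounds shown leave open whether iodo in place of chloro on this aromatic carbon changes inhibition at all, and in which direction.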